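The source may hold more compounds than are shown below. What is called first, only, known or untested is meant among the compounds shown, and "the series" means these compounds.

Compound 1 `N#CC(/C=C/[C@@H](O)C[C@@H](O)CC(=O)O)=C(c1ccc(F)cc1)c1ccc(F)cc1` gives 8000 nM in an assay for inhibition of 3-hydroxy-3-methylglutaryl-coenzyme A reductase (Rattus norvegicus); on this read-out lower numbers stand for stronger inhibition and higher numbers for weaker inhibition.
Compound 2 `CC(C)n1nnc(C(/C=C/[C@@H](O)C[C@@H](O)CC(=O)O)=C(c2ccc(F)cc2)c2ccc(F)cc2)n1` gives only a limit of the assay, > 300000 nM.
Compound 3 `Cn1nnnc1C(/C=C/[C@@H](O)C[C@@H](O)CC(=O)O)=C(\c1ccccc1)c1ccc(F)cc1` gives 44 nM in this assay.

Of the two numbers shown, compound 3 has the lowest, well below the number for compound 1, while compound 2 yields a limit rather than a number. Within the data shown here, the one measured step, an at least 37-fold higher number from compound 1 to compound 2 (1.57 log units; beyond the scatter), exchanges the group on the doubly bonded chain carbon of the shared core and is large, but it tells nothing about a change on the aromatic rings.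

Compound 4 `Cn1nnnc1C(/C=C/[C@@H](O)C[C@@H](O)CC(=O)O)=C(c1ccccc1)c1ccccc1` differs from compound 3 in one place: hydrogen in place of fluoro on an aromatic carbon. Among the measured compounds shown here, no measured step touches this position, so there is no direct guide. Compound 1 and compound 2 both carry fluoro on both rings, compound 3 on one; none shows what a second removal does. The expectation therefore rests on the small size of the change: a step of a 1.8-fold higher number from compound 3 to compound 4 (0.26 log units; within the scatter) in this assay, somewhat weaker binding but not clearly beyond the scatter. For compound 4 the estimate in this assay is 80 nM, with a range from 30 nM to 250 nM.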

Compound 4, half-maximal inhibitory concentration: 190 nM
Compound 4: the middle estimate sits 2.4-fold (0.38 log units) below what was measured, within the range that was stated.
By their numbers in this assay, from the lowest: compound 3; then compound 4; then compound 1. At a limit, above all of these: compound 2.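

Taking away the fluoro on an aromatic carbon, para to a large group, now has a direct measurement: in this assay this exchange for hydrogen gives a 4.3-fold higher number from compound 3 to compound 4 (0.64 log units; beyond the scatter), a modest step towards weaker inhibition that lies beyond the usual scatter of the assay. Among these compounds, the one earlier step changed the group on the doubly bonded chain carbon and left the rings alone, so this is the first sign that a single ring atom, swapped for hydrogen, can shift the result measurably on the shared core. Nothing among the data shown accounts for why this exchange weakens inhibition.

As far as these compounds go, it remains open whether the same exchange would have a similar effect alongside the nitrile of compound 1, which has no partner here that differs from it only by the loss of a fluoro. The compounds shown also leave open how a chloro, methyl or methoxy group at this position would compare with fluoro and hydrogen, and what fluoro on the second ring would add to compound 3.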